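Benzyl Replaces Phenyl on the Amide of Compound 3

A few compounds are considered here, and "the series" means these few. Any claim that something is new, unique, unknown or untested is made for them only; others in the source may bear on it.

Compound 1 `COc1cc(NC(=O)c2csc(-c3c[nH]c4ccc(Br)cc34)n2)cc(OC)c1OC` in a functional assay on PC-3 cells (Homo sapiens) for cytotoxicity, read by MTT assay, with a stated time of 48 h, in the absence of a further agent (on this read-out higher numbers stand for weaker inhibition and lower numbers for stronger inhibition), gives > 100000 nM, a limit of the assay and not a number.
Compound 2 `O=C(Nc1ccccc1)c1csc(-c2cn(Cc3ccc(Cl)cc3)c3ccccc23)n1` gives 76400 nM.
Compound 3 `O=C(Nc1ccccc1)c1csc(-c2c[nH]c3ccccc23)n1` gives > 100000 nM, again a limit rather than a number.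

Compound 3 therefore stands at the limit of > 100000 nM in this assay, at which 2 of the 3 values shown sit. Among the compounds with values here, the only measured step, an at least 1.3-fold higher number from compound 2 to compound 3 (0.11 log units; that floor lies within the scatter), hydrogen in place of 4-chlorobenzyl on an aromatic nitrogen, is itself a floor and lies within the scatter. Compound 4 `O=C(NCc1ccccc1)c1csc(-c2c[nH]c3ccccc23)n1` differs from compound 3 by benzyl in place of phenyl on an amide-type nitrogen. No measured step concerns an amide-type nitrogen; the one step shown concerns an aromatic nitrogen, so no measured step bears directly on this change. The data give no ground for a shift beyond the scatter in this assay in either direction. Compound 4 is accordingly expected at 150000 nM, with a range from 60000 nM to 400000 nM, and most probably reported only as a limit. The step this estimate means, a step that the limit leaves unreadable from compound 3 to compound 4, is expected to stay within the scatter.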

Compound 4, half-maximal inhibitory concentration: > 100000 nM
Compound 4: a limit, no number; the forecaster's own chance of this, stated with the estimate: 70%; the middle value is on the limit's open side.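

Within the data shown here, compound 3 and compound 4 both stand only as limits in this assay, so no step between them can be read, and the result adds one more entry at that ceiling: the limit of > 100000 nM in this assay, at which 3 of the 4 values shown sit. The compounds shown leave open whether benzyl or phenyl on the amide-type nitrogen gives stronger inhibition.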